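A Limit, and a Group Borrowed from Compound 1

This account rests on a few compounds, and the source may have more. Where it says the series, first, only, none or still open, it means among the compounds named here.

In a functional assay on HepG2 cells (Homo sapiens) for inhibition, read by MTT assay, with a stated time of 48 h (a lower number here means a stronger inhibitor, a higher number a weaker inhibitor), compound 1 (`COc1ccc(-n2c(SCC(=O)c3ccc(F)cc3)nnc2-c2cc(OC)c(OC)c(OC)c2)cc1`) gives 10700 nM as its value. Compound 2 (`COc1ccc(CSc2nnc(-c3cc(OC)c(OC)c(OC)c3)n2-c2ccc(N(C)C)cc2)cc1`) stands at > 60000 nM in that assay, which is a limit and not a number. Compound 3 (`COc1cc(-c2nnc(SCC(=O)c3ccc(F)cc3)n2-c2ccc(N(C)C)cc2)cc(OC)c1OC`) has (4-fluorophenyl)carbonyl in place of 4-methoxyphenyl on a saturated chain carbon bound to a sulfur. Compound 1 carries the same group and gives 10700 nM as its value, which points towards a stronger inhibitor. The expected step (an at least 3.7-fold lower number from compound 2 to compound 3 (0.57 log units; beyond the scatter)) lies beyond the scatter. Compound 3 is estimated at 16000 nM in this assay with a range from 5000 nM to 50000 nM as expected bounds.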

Compound 3, half-maximal inhibitory concentration: > 60000 nM
Compound 3 was reported as a limit (the forecaster's own chance of this, stated with the estimate: 15%); middle value at least 3.7-fold (0.57 log units) away from the limit.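

With (4-fluorophenyl)carbonyl held in place, dimethylamino in place of methoxy on an aromatic carbon goes with an at least 5.6-fold higher number from compound 1 to compound 3 (0.74 log units; beyond the scatter) in this assay. Among these compounds, the group on the saturated chain carbon bound to a sulfur therefore gives a measured number only in compound 1, not alongside dimethylamino. Compound 2 and compound 3 each stand at a limit, so the step between them cannot be read: the limit of > 60000 nM in this assay, at which 2 of the 3 values shown sit.

Going by these compounds, what a hydroxyl or a chlorine on that aromatic carbon would give stays open. So does the value of 4-methoxyphenyl on the chain carbon alongside methoxy.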